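This account rests on a few compounds, and the source may have more. Where it says the series, first, only, none or still open, it means among the compounds named here.

Working notes on the series. For the measured compounds named here, compound 1 `CCNC(=O)c1cc(Oc2ccc(NC(=O)c3nn(-c4ccccc4C)c(=O)cc3C)cc2)ccn1` is the only member with a number: in a functional assay on MCF7 cells (Homo sapiens) for antiproliferative activity, read by MTT assay, with a stated time of 72 h (a lower number here means a stronger inhibitor, a higher number a weaker inhibitor), compound 1 gives 44300 nM, a weak result on its own. Compound 2 `CNC(=O)c1cc(Oc2ccc(NC(=O)c3nn(-c4ccccc4)c(=O)cc3C)cc2F)ccn1` is reported in this assay without a number; for compound 2 the record reads "not active" (no number reported). Compound 3 `CCNC(=O)c1cc(Oc2ccc(NC(=O)c3nn(-c4ccc(Br)cc4F)c(=O)cc3C)cc2)ccn1` has not been measured in this assay. It differs from compound 1 in one place: 4-bromo-2-fluorophenyl in place of 2-methylphenyl on an aromatic nitrogen. Going by the values given here, no measured pair shows what such a change does here, so no step beyond the scatter is expected; the estimated step of a 1.2-fold lower number from compound 1 to compound 3 (0.07 log units; within the scatter) stays small. Compound 3 is therefore expected near 38000 nM, within 12000 nM to 120000 nM.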

Compound 3, half-maximal inhibitory concentration: 35100 nM
Compound 3: middle estimate off by 1.1-fold (0.03 log units), on the high side, and the stated range covers the measured number.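

The step of a 1.3-fold lower number from compound 1 to compound 3 (0.10 log units; within the scatter) in this assay shows that, on this aromatic nitrogen, 4-bromo-2-fluorophenyl and 2-methylphenyl cannot be told apart. This position therefore takes two differently substituted phenyl groups with the read-out staying within the scatter, and both compounds remain at the same weak level. Nothing available accounts for this result.

From the compounds shown here alone, it remains open whether a group other than a substituted phenyl on this nitrogen, such as a longer alkyl chain, an amine or a carboxylic acid, would move the number beyond the scatter.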